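The compounds below may be only part of what the source reports. "The series", "measured", "known", "first", "only" and "open" are said of these compounds alone.

Measured so far in an assay on CHO-K1 cells for displacement of a labelled ligand from prostaglandin E2 receptor EP1 subtype (Homo sapiens); on this read-out higher numbers stand for weaker inhibition and lower numbers for stronger inhibition:
compound 1 `Cc1cc(C(N)=O)nn1Cc1cc(Cl)ccc1OCc1ccccc1` gives 126 nM
compound 2 `Cc1cc(C(=O)NC(C)C)nn1Cc1cc(Cl)ccc1OCc1ccccc1` gives 126 nM
compound 3 `Cc1cc(C(=O)Nc2c(F)cccc2F)nn1Cc1cc(Cl)ccc1OCc1ccccc1` gives 10 nM

Compound 1 stands level with compound 2 at the digits shown, the pair together giving the highest numbers of the three; compound 3 lies furthest from it. The single-point steps read no change at the digits printed from compound 1 to compound 2 (within the scatter), a 13-fold lower number from compound 1 to compound 3 (1.10 log units; beyond the scatter) and a 13-fold lower number from compound 2 to compound 3 (1.10 log units; beyond the scatter).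

Compound 4 `Cc1cc(C(=O)Nc2ccccn2)nn1Cc1cc(Cl)ccc1OCc1ccccc1` is not yet measured. Against compound 1 the change is pyridin-2-yl in place of hydrogen on an amide-type nitrogen. For the measured compounds named here, the step that bears on it most is the one to compound 3, where a six-membered aromatic ring also entered on the amide-type nitrogen and the number fell by a large margin; the step to compound 2 shows that an isopropyl there brought no change. Pyridin-2-yl carries no fluorine and one ring nitrogen, and only one aromatic example exists, so the size is uncertain. The expected step is a 4.2-fold lower number from compound 1 to compound 4 (0.62 log units; beyond the scatter), in the direction seen for compound 3 but probably smaller. Compound 4 is estimated at 30 nM, within 8 nM to 100 nM.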

Compound 4, half-maximal inhibitory concentration: 126 nM
Beside the measured number, compound 4's estimate is 4.2-fold (0.62 log units) below it; measured number outside the range, above it.
By their numbers in this assay, from the lowest: compound 3; then compounds 1, 2 and 4 (each within the scatter of the next).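

In this assay, an aromatic ring on the amide-type nitrogen does not by itself lower the number: pyridin-2-yl in place of hydrogen reads as no change at the digits printed from compound 1 to compound 4 (within the scatter), and pyridin-2-yl in place of isopropyl reads as no change at the digits printed from compound 2 to compound 4 (within the scatter). The low number of compound 3 thus goes with 2,6-difluorophenyl and not with every six-membered aromatic ring at this position, as pyridin-2-yl in place of 2,6-difluorophenyl gives (a 13-fold higher number from compound 3 to compound 4 (1.10 log units; beyond the scatter)). Nothing available explains why these two rings part so widely.

Open, going by these compounds, is whether unsubstituted phenyl on the amide-type nitrogen would stand with compound 3 or with compound 4, which would separate the part played by the two fluorines from that of the ring nitrogen. Also open, on these data alone, is how 2-fluorophenyl or pyridin-3-yl would read at the same place.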